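A few compounds are considered here, and "the series" means these few. Any claim that something is new, unique, unknown or untested is made for them only; others in the source may bear on it.

Working notes on the series. Compound 1 `O=C(NO)C1(S(=O)(=O)c2ccc(Oc3ccc(Cl)cc3)cc2)CCNCC1` in an in vivo ADME assay on the whole organism for metabolic stability, with Rattus norvegicus as the target (a lower number here means that the compound disappears faster, a higher number that the compound lasts longer), gives 1.8 h. Compound 2 `O=C(NO)C1(S(=O)(=O)c2ccc(Oc3ccc(Cl)cc3)cc2)CCN(C2CC2)CC1` in this assay gives 0.74 h. Within the data shown here, the single measured step is a 2.4-fold lower number from compound 1 to compound 2 (0.39 log units; beyond the scatter). Compound 2 thus stands lowest of the two numbers, with compound 1 the nearest neighbour above it.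

Compound 3 `CC(=O)N1CCC(C(=O)NO)(S(=O)(=O)c2ccc(Oc3ccc(Cl)cc3)cc2)CC1` differs from compound 2 by acetyl in place of cyclopropyl on an amine nitrogen in a ring. Among the measured compounds shown here, the only step that bears on this is the one from compound 1 to compound 2, which involves the same ring nitrogen and was modest in size; no measured step covers an acetyl at this position, so the direction for compound 3 is open. A step of at most modest size in this assay is expected, with a mild lean back toward the number of compound 1, i.e. a 1.6-fold higher number from compound 2 to compound 3 (0.21 log units; within the scatter). Compound 3 is therefore estimated at 1.2 h, within a range from 0.5 h to 3 h.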

Compound 3, half-life: 0.86 h
Beside the measured number, compound 3's estimate is 1.4-fold (0.14 log units) above it; low and high end bracket the measured number.
By their numbers in this assay, from the lowest: compounds 2 and 3 (each within the scatter of the next); then compound 1.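

In this assay, acetyl in place of cyclopropyl on the amine nitrogen in the ring gives a 1.2-fold higher number from compound 2 to compound 3 (0.07 log units; within the scatter), so these two groups, each of the same heavy-atom count, one a carbon-only ring and the other with a hydrogen-bond acceptor, are not told apart here. Acetyl in place of hydrogen gives a 2.1-fold lower number from compound 1 to compound 3 (0.32 log units; beyond the scatter), so the lower number seen with cyclopropyl is not confined to that group, and among these three compounds both substituted nitrogens sit apart from the unsubstituted one. No evidence at hand bears on the reason for this result.

Going by these compounds, whether a longer chain such as n-butyl, a benzyl group or a methanesulfonyl group on this nitrogen would fall with compound 2 and compound 3 or with compound 1 stays open. On these data alone, the size of any such step also remains unknown for groups outside this set.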